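Swapping the methanesulfonamido chain for a hydroxypyrrolidine ring

The source may hold more compounds than are shown below. What is called first, only, known or untested is meant among the compounds shown, and "the series" means these compounds.

Compound 1 `COc1cc[nH]c1/C=C1\C(=O)Nc2ccc(F)c(C#C[C@H](C)O)c21` gives 400 nM in a functional assay on SW480 cells (Homo sapiens) for inhibition; on this read-out higher numbers stand for weaker inhibition and lower numbers for stronger inhibition
Compound 2 `COc1cc[nH]c1/C=C1\C(=O)Nc2ccc(F)c(C#C[C@@H](NS(C)(=O)=O)[C@@H](C)O)c21` gives 1190 nM in this assay

Compound 2 stands highest of the two measured compounds, at 1190 nM in this assay. Compound 3 `COc1cc[nH]c1/C=C1\C(=O)Nc2ccc(F)c(C#C[C@@H]3C[C@H](O)CN3)c21` carries 4-hydroxypyrrolidin-2-yl in place of 2-hydroxy-1-(methanesulfonamido)propyl on a triple-bonded carbon. Going by the values given here, only one measured step bears on this, a 3.0-fold higher number from compound 1 to compound 2 (0.47 log units; beyond the scatter), which is modest and brought in the chain that now leaves. Among the compounds with values here, no measured compound carries the entering ring, so a modest move to a lower number is expected, with real uncertainty. The expected change in this assay is a 2.2-fold lower number from compound 2 to compound 3 (0.34 log units; beyond the scatter) overall. Compound 3 is estimated at 550 nM, with an expected range from 170 nM to 1800 nM in this assay.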

Compound 3, half-maximal inhibitory concentration: 90 nM
The estimate for compound 3 lay 6.1-fold (0.79 log units) above the measured number, outside the stated range (below it).
By their numbers in this assay, from the lowest: compound 3; then compound 1; then compound 2.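

In this assay, the 4-hydroxypyrrolidin-2-yl ring on a triple-bonded carbon gives a 13-fold lower number from compound 2 to compound 3 (1.12 log units; beyond the scatter) against the 2-hydroxy-1-(methanesulfonamido)propyl chain, and a 4.4-fold lower number from compound 1 to compound 3 (0.65 log units; beyond the scatter) against 1-hydroxyethyl. The rise seen with the methanesulfonamido chain therefore does not hold for every replacement of 1-hydroxyethyl at this position, and a ring here can lower the number. Nothing available explains this gain. The compounds shown leave open whether the hydroxyl on the ring is needed, and how a plain pyrrolidine or a piperidine ring would compare.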